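Adding a Second Decyloxy Chain to a Selectin Binder

The source may report more compounds than this note shows. Statements on the series, on what has been measured and on what is new or still open speak of the compounds shown alone.

Compound 1, with the structure `CCCCCCCCCCOc1cccc(OCCCCCC(=O)N(Cc2ccc(C(=O)O)cc2)c2cccc(C(=O)O)c2)c1`, carries one decyloxy chain on its aromatic core and two carboxylic acids on the amide side. In an assay on isolated protein for binding affinity to L-selectin (Homo sapiens), read by ELISA, tested at 500 uM (a lower number here means less inhibition, a higher number more inhibition at the concentration tested (going by the name of the read-out)), compound 1 gives 103%, the higher of the two numbers available. Compound 2, `CCCCCCCCCCOc1cc(OCCCCCCCCCC)cc(OCCCCCC(=O)N(c2ccc(C(=O)OC)cc2)c2ccc(C(=O)OC)cc2)c1`, has two decyloxy chains but methyl esters in place of the acids and no benzyl link; in this assay compound 2 gives 16%, a result far below that of compound 1 and beyond the usual scatter. Compound 3, `CCCCCCCCCCOc1cccc(OCCCCCC(=O)N(Cc2ccc(C(=O)O)cc2)c2ccc(C(=O)O)cc2)c1`, was run in this assay but reported as "not determined" (no result reported), so it adds no number.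

Compound 4, `CCCCCCCCCCOc1cc(OCCCCCCCCCC)cc(OCCCCCC(=O)N(Cc2ccc(C(=O)O)cc2)c2cccc(C(=O)O)c2)c1`, is compound 1 with one change: decyloxy in place of hydrogen on an aromatic carbon. Among the measured compounds shown here, no pair of measured compounds shows this exact step, so its size is uncertain. The free acids that compound 1 keeps are retained in compound 4, and compound 2 alters several features at once, so its low number cannot be laid on the second chain alone. A modest loss is expected for compound 4, with the step from compound 1 to compound 4 estimated as a number 28 percentage points lower from compound 1 to compound 4 (beyond the scatter). In this assay compound 4 is expected to give about 75%, within a range from 35% to 105%.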

Compound 4, a percentage reported as inhibition, at one concentration (the size of the read-out at that concentration, not a potency): 92%
For compound 4 the middle estimate is 17 percentage points below the measured one, and the stated range covers the measured number.
By their numbers in this assay, from the lowest: compound 2; then compound 4; then compound 1.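

In this assay, placing decyloxy in place of hydrogen on an aromatic carbon, meta to a decyloxy group and meta to a large group, gives a number 11 percentage points lower from compound 1 to compound 4 (beyond the scatter). Among the compounds shown here, this is the first comparison here in which only one place changes, so the cost of the second decyloxy chain can now be read on its own: the step is modest, and compound 4 still gives 92% as a single-concentration reading rather than a potency. Nothing available explains why the step has this size.

From the compounds shown here alone, whether a methoxy group or an amine on this same aromatic carbon would give a similar reading remains open, as does whether a longer chain would widen the step. The separate contribution of the two carboxylic acids also stays unresolved: compound 2 differs from compound 4 in more than one place, so that pair cannot isolate the acids.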